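A nitro group in place of hydroxy

A few compounds are considered here, and "the series" means these few. Any claim that something is new, unique, unknown or untested is made for them only; others in the source may bear on it.

Measured in a functional assay on HT-29 cells (Homo sapiens) for cytotoxicity, read by XTT assay, with a stated time of 72 h; on this read-out higher numbers stand for weaker inhibition and lower numbers for stronger inhibition:
compound 1 `COc1ccc(Cc2cc(OC)c(OC)c(OC)c2)cc1N`: 41 nM
compound 2 `COc1ccc(Cc2cc(OC)c(OC)c(OC)c2)cc1O`: 440 nM
compound 3 `CCn1ccc2cc(C(O)c3ccc(OC)c(OC)c3OC)ccc21`: > 10000 nM, a limit of the assay

Of the two exact numbers in this assay, compound 2 has the higher, at 440 nM. Compound 4 `COc1ccc(Cc2cc(OC)c(OC)c(OC)c2)cc1[N+](=O)[O-]` shares its core and differs by nitro in place of hydroxy on an aromatic carbon, with nitro in place of hydroxy on an aromatic carbon, ortho to a methoxy group. For the measured compounds named here, the one measured step at this place is large: an 11-fold higher number from compound 1 to compound 2 (1.03 log units; beyond the scatter). Going by the values given here, it shows that this place can respond strongly, but no measured compound carries nitro, so only a moderate further rise is expected. The expected change is a 3.4-fold higher number from compound 2 to compound 4 (0.53 log units; beyond the scatter). For compound 4 the estimate is 1500 nM, with an expected range of 300 nM to 8000 nM.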

Compound 4, half-maximal inhibitory concentration: 60 nM
Estimate against measurement, compound 4: 25-fold (1.40 log units) above; the whole stated range lies above it.
By their numbers in this assay, from the lowest: compounds 1 and 4 (each within the scatter of the next); then compound 2. At a limit, above all of these: compound 3.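

Replacing hydroxy with nitro gives a 7.3-fold lower number from compound 2 to compound 4 (0.87 log units; beyond the scatter), a move opposite in direction to the one the hydroxy-for-amino exchange had shown. Amino and nitro, which the earlier compounds did not compare, cannot be told apart at this position: a 1.5-fold higher number from compound 1 to compound 4 (0.17 log units; within the scatter). Of the three groups, hydroxy alone separates from the others, and nothing given here bears on why. From the compounds shown here alone, whether a methylamino group, an acetamide or a carboxylic acid at this place would match amino and nitro remains open. So does whether these exchanges would hold on a different core.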